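The source may hold more compounds than are shown below. What is called first, only, known or untested is meant among the compounds shown, and "the series" means these compounds.

Compound 1, `COC(=O)/C=C/c1cccc(N(Cc2ccc(/C=C/c3ccc(F)cc3)cc2)C(=O)C(C)C)c1`, sets the reference point: in an assay on isolated protein with Bile acid receptor (Homo sapiens) as the target (a higher number here means that more compound is needed for the effect, a lower number that less compound is needed), compound 1 gives 120 nM. Compound 2, `CC(C)(C)OC(=O)/C=C/c1ccc(CN(C(=O)C2CCCCC2)c2cccc(/C=C/C(N)=O)c2)cc1`, carries a carbamoyl group on its ethenyl chain and a cyclohexanecarbonyl amide in place of the isobutyryl amide of compound 1. In this assay compound 2 reaches only the limit of the measurement, > 1000 nM, so no number stands behind it; this is noted as the limit of > 1000 nM in this assay, at which 1 of the 2 values shown sits. Compound 3, `COC/C=C/c1cccc(N(Cc2ccc(/C=C/C(=O)OC(C)(C)C)cc2)C(=O)C2CCCCC2)c1`, follows from compound 2 by a single change: methoxymethyl in place of carbamoyl on a double-bonded chain carbon bound to a double-bonded chain carbon. For the measured compounds named here, no measured pair shows what this swap does, so the expectation rests on compound 2 alone and is worded with caution. Compound 3 is expected to sit near the range where compound 2 stands, with the step that the limit leaves unreadable from compound 2 to compound 3 not clearly beyond the scatter in either direction. In this assay compound 3 is estimated at 1500 nM, between 300 nM and 8000 nM.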

Compound 3, half-maximal effective concentration: 243 nM
Beside the measured number, compound 3's estimate is 6.2-fold (0.79 log units) above it; the measured number lies below the stated range.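

In this assay, this position turns out to respond to what sits at the end of the chain: methoxymethyl in place of carbamoyl on a double-bonded chain carbon bound to a double-bonded chain carbon gives an at least 4.1-fold lower number from compound 2 to compound 3 (0.61 log units; beyond the scatter). The swap replaces a group with a hydrogen-bond donor and acceptor by one with an acceptor and no donor, and the number falls with it. The step can be given only as a minimum because compound 2 stands at a limit and has no number of its own: the limit of > 1000 nM in this assay, at which 1 of the 3 values shown sits.

This one pair cannot separate the loss of the donor from the other differences between the two groups. The compounds shown also leave open how a carboxylic acid or an amine would fare at this place, and whether the step would hold with the isobutyryl amide of compound 1.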